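The source may report more compounds than this note shows. Statements on the series, on what has been measured and on what is new or still open speak of the compounds shown alone.

Measured in an assay on isolated protein for inhibition of tyrosine-protein kinase receptor UFO (Homo sapiens), read by ELISA; a higher number here means a weaker inhibitor, a lower number a stronger inhibitor:
compound 1 `Cn1cc(-c2ccc(NC(=O)c3cn(CC4CCCCC4)cc(-c4ccc(F)cc4)c3=O)cc2)c2c(N)ncnc21` — 2.3 nM
compound 2 `Cn1cc(-c2ccc(NC(=O)c3cn(CC4CCCO4)cc(-c4ccc(F)cc4)c3=O)cc2)c2c(N)ncnc21` — 1.2 nM

Compound 2 carries the smaller of the two numbers, but the step of a 1.9-fold lower number from compound 1 to compound 2 (0.28 log units; within the scatter) is covered by the scatter, so compound 1 and compound 2 are not separated in this assay. Compound 3 `Cn1cc(-c2ccc(NC(=O)c3cn(C4CCOCC4)cc(-c4ccc(F)cc4)c3=O)cc2)c2c(N)ncnc21` differs from compound 2 by oxan-4-yl in place of (oxolan-2-yl)methyl on an aromatic nitrogen. Among the measured compounds shown here, the only step that bears on this change is the one at the same nitrogen, from compound 1 to compound 2, which stayed within the scatter; a saturated ring of similar size with one oxygen is exchanged for another. No step beyond the scatter is therefore expected, and compound 3 is estimated at 1.5 nM (range 0.6 nM to 4 nM), a step of a 1.3-fold higher number from compound 2 to compound 3 (0.10 log units; within the scatter) from compound 2.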

Compound 3, half-maximal inhibitory concentration: 1.1 nM
Beside the measured number, compound 3's estimate is 1.4-fold (0.13 log units) above it, and the stated range covers the measured number.
By their numbers in this assay, from the lowest: compounds 3, 2 and 1 (each within the scatter of the next, the first and the last beyond it).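

At the aromatic nitrogen, a 1.1-fold lower number from compound 2 to compound 3 (0.04 log units; within the scatter) in this assay shows that oxan-4-yl, with no methyl link, is accepted as well as (oxolan-2-yl)methyl. Against cyclohexylmethyl, the same group gives a 2.1-fold lower number from compound 1 to compound 3 (0.32 log units; beyond the scatter) as the first step at this position beyond the scatter, though a modest one, while compound 2 lies within the scatter of both. No evidence bears on these steps.

Open, from the compounds shown here alone, is whether piperidin-4-yl or a carboxylic acid on a short chain at this nitrogen would keep this level. Also open, going by these compounds, is whether cyclohexyl set directly on the nitrogen would match compound 3, which would separate the ring oxygen from the methyl link.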